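Swapping the Chlorothiophene for a Formylthiophene

A few compounds are considered here, and "the series" means these few. Any claim that something is new, unique, unknown or untested is made for them only; others in the source may bear on it.

In a functional assay on MV4-11 cells (Homo sapiens) for inhibition, read by resazurin assay, with a stated time of 72 h (on this read-out higher numbers stand for weaker inhibition of growth and lower numbers for stronger inhibition of growth), compound 1 (`O=C1NCCC12CCN(c1c(Cl)cncc1-c1ccoc1)CC2`) gives 750 nM and compound 2 (`Cc1csc(-c2cncc(Cl)c2N2CCC3(CCNC3=O)CC2)c1`) gives 650 nM on a shared core. Compound 3 (`O=C1NCCC12CCN(c1c(Cl)cncc1-c1ccc(Cl)s1)CC2`) gives 560 nM and stands within the scatter of both of them. The next compound, compound 4 (`O=Cc1cscc1-c1cncc(Cl)c1N1CCC2(CCNC2=O)CC1`), carries 4-formylthiophen-3-yl in place of 5-chlorothiophen-2-yl on an aromatic carbon, ortho to a large group. Three measured steps change the group at this same place. They are a 1.2-fold lower number from compound 1 to compound 2 (0.06 log units; within the scatter) and a 1.3-fold lower number from compound 1 to compound 3 (0.13 log units; within the scatter) and also a 1.2-fold lower number from compound 2 to compound 3 (0.06 log units; within the scatter), and all of them stay within the scatter. Within the data shown here, no measured compound carries a formyl group, so these steps are only a partial guide, and they give no ground for expecting a move beyond the scatter in either direction. The expected size of the change is a 1.2-fold higher number from compound 3 to compound 4 (0.06 log units; within the scatter) and no more. In this assay compound 4 is estimated at 650 nM with a range from 250 nM to 1700 nM.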

Compound 4, concentration for 50% growth inhibition: 27100 nM
Compound 4: middle estimate off by 42-fold (1.62 log units), on the low side, outside the stated range (above it).
By their numbers in this assay, from the lowest: compounds 3, 2 and 1 (each within the scatter of the next); then compound 4.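

Among these compounds, the position is not as indifferent as the earlier compounds suggested: furan-3-yl, 4-methylthiophen-2-yl and 5-chlorothiophen-2-yl all lie within the scatter of one another, whereas 4-formylthiophen-3-yl breaks sharply away from them in this assay. The change is large against each of the three, with a 48-fold higher number from compound 3 to compound 4 (1.68 log units; beyond the scatter), a 42-fold higher number from compound 2 to compound 4 (1.62 log units; beyond the scatter) and a 36-fold higher number from compound 1 to compound 4 (1.56 log units; beyond the scatter). All four groups contain one five-membered aromatic ring with one hetero atom, so that ring type alone does not keep activity at this position.

Nothing shown here accounts for the large step. The compounds leave open whether the formyl group itself or its placement on the thiophene carries the step, and whether a hydroxymethyl group, a carboxylic acid or an aminomethyl group on the same ring would behave alike.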